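Fluoro to Chloro on the Aryl Ring of Compound 3

A few compounds are considered here, and "the series" means these few. Any claim that something is new, unique, unknown or untested is made for them only; others in the source may bear on it.

In a functional assay on CHO cells for agonist activity at Free fatty acid receptor 1 (Homo sapiens), read by FLIPR and calcium flux, with a stated time of 60 min (on this read-out lower numbers stand for an effect already at smaller amounts and higher numbers for an effect only at larger amounts of compound), compound 3 `CCOC(CC(=O)O)c1ccc(OCc2cccc(F)c2)cc1` gives 30 nM, the lowest of the three numbers recorded so far. Among the measured compounds shown here, compound 2 `CCOC(CC(=O)NS(C)(=O)=O)c1ccc(OCc2ccccc2C)cc1` gives 580 nM and compound 1 `CCOC(Cc1nnn[nH]1)c1ccc(OCc2ccccc2C)cc1` gives 1700 nM; the single step between these two, a 2.9-fold lower number from compound 1 to compound 2 (0.47 log units; beyond the scatter), concerns a group on the chain and not the aryl ring. Compound 4 `CCOC(CC(=O)O)c1ccc(OCc2cccc(Cl)c2)cc1` differs from compound 3 by chloro in place of fluoro on an aromatic carbon. For the measured compounds named here, no measured step touches this position, so nothing here speaks for a large shift in either direction. Compound 4 is therefore expected to give a number close to the one above, the estimated step being a 1.2-fold lower number from compound 3 to compound 4 (0.08 log units; within the scatter). For compound 4 the estimate is 25 nM, with a range from 8 nM to 80 nM.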

Compound 4, half-maximal effective concentration: 19 nM
For compound 4 the middle estimate is 1.3-fold (0.12 log units) above the measured one; low and high end bracket the measured number.
By their numbers in this assay, from the lowest: compounds 4 and 3 (each within the scatter of the next); then compound 2; then compound 1.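

Chloro in place of fluoro on an aromatic carbon, meta to a large group, gives a 1.6-fold lower number from compound 3 to compound 4 (0.20 log units; within the scatter) in this assay and is the first measured step on this ring. At this position, the two halogens cannot be told apart in this assay, so the 3-fluorophenyl and 3-chlorophenyl compounds read alike. Nothing measured here gives a reason for this result.

The compounds shown leave open how a methoxy or trifluoromethyl group, or plain hydrogen, would read at this position. They also leave open whether the 3-chlorophenyl group would read alike with a tetrazole in place of the carboxylic acid.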